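Trifluoromethyl for chloro on the pendant phenyl ring

The source may hold more compounds than are shown below. What is called first, only, known or untested is meant among the compounds shown, and "the series" means these compounds.

Measured so far:
compound 1 `CC/C(=C(/c1ccc(/C=C/C(=O)O)cc1)c1cc2ccccc2[nH]1)c1ccccc1` — 108 nM
compound 2 `CC/C(=C(/c1ccc(/C=C/C(=O)O)cc1)c1cc2ccccc2[nH]1)c1ccccc1C(F)(F)F` — 8 nM
compound 3 `CC/C(=C(/c1ccc(/C=C/C(=O)O)cc1)c1cc2ccccc2[nH]1)c1ccc(Cl)cc1` — 343 nM

In a functional assay on MCF7 cells (Homo sapiens) for inhibition (on this read-out higher numbers stand for weaker inhibition and lower numbers for stronger inhibition), compound 3 gives the highest of the three numbers; compound 1 comes nearest, compound 2 lies furthest away. The step of a 3.2-fold higher number from compound 1 to compound 3 (0.50 log units; beyond the scatter) and the step of a 43-fold higher number from compound 2 to compound 3 (1.63 log units; beyond the scatter) both place compound 3 well beyond the scatter from each measured neighbour.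

Compound 4 `CC/C(=C(/c1ccc(/C=C/C(=O)O)cc1)c1cc2ccccc2[nH]1)c1ccc(C(F)(F)F)cc1` is not yet measured. It differs from compound 3 by trifluoromethyl in place of chloro on an aromatic carbon.

Among the measured compounds shown here, no measured step exchanges chloro for trifluoromethyl directly. For the measured compounds named here, two steps bear on it indirectly: a 14-fold lower number from compound 1 to compound 2 (1.13 log units; beyond the scatter) shows trifluoromethyl on the pendant ring giving a large drop in number, but at another position; a 3.2-fold higher number from compound 1 to compound 3 (0.50 log units; beyond the scatter) shows chloro at the position in question raising the number modestly. Trifluoromethyl at this same position has no precedent in the set, so the direction is open. The expectation for the step of a 1.1-fold lower number from compound 3 to compound 4 (0.06 log units; within the scatter) is therefore a small move of uncertain direction, possibly within scatter.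

Compound 4 is estimated at 300 nM in this assay, expected between 90 nM and 1000 nM.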

Compound 4, half-maximal inhibitory concentration: 139 nM
Compound 4: the middle estimate sits 2.2-fold (0.33 log units) above what was measured; low and high end bracket the measured number.
By their numbers in this assay, from the lowest: compound 2; then compounds 1 and 4 (each within the scatter of the next); then compound 3.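

In this assay, trifluoromethyl in place of chloro on the aromatic carbon para to a large group gives a 2.5-fold lower number from compound 3 to compound 4 (0.39 log units; beyond the scatter) and shows that the higher number seen with chloro here does not extend to every substituent at this position. Against the unsubstituted ring, the step is a 1.3-fold higher number from compound 1 to compound 4 (0.11 log units; within the scatter) and leaves trifluoromethyl at this position level with hydrogen. The same group does not read alike at both positions on the pendant ring: 4-(trifluoromethyl)phenyl in place of 2-(trifluoromethyl)phenyl gives a 17-fold higher number from compound 2 to compound 4 (1.24 log units; beyond the scatter) and ties the low number of compound 2 to the 2-(trifluoromethyl)phenyl arrangement.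

As far as these compounds go, whether a methoxy group or an amine at the position para to a large group would stay level with hydrogen remains open. Nothing available accounts for these differences.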